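The source may report more compounds than this note shows. Statements on the series, on what has been measured and on what is new or still open speak of the compounds shown alone.

Working notes on the series.

Three compounds have been run in a functional assay on HepG2 cells (Homo sapiens) for antiproliferative activity, read by CCK-8 assay, with a stated time of 72 h, tested at 2 uM; on this read-out higher numbers stand for a stronger effect at the one concentration tested and lower numbers for a weaker effect. Compound 1 `COC(CCn1cnc2c(NCc3ccc(C(=O)Nc4ccccc4N)cc3)nc(Cl)nc21)OC` gives 8.52% in this assay; compound 2 `CC(C)n1cnc2c(Nc3ccccc3)nc(NCOCc3ccc(/C=C/C(=O)Nc4ccccc4N)cc3)nc21` gives 1.46% in this assay; compound 3 `CC1CCN(c2nc(Cl)nc3c2ncn3Cc2ccc(C(=O)Nc3ccccc3N)cc2)CC1` gives 1.22% in this assay. On the numbers shown, compound 1 holds the top place of the three, but its gaps to compound 2 and to compound 3 both lie within the scatter, so no ranking among them can be read from the numbers. All three sit near the bottom of the read-out.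

Compound 4 `Nc1ccccc1NC(=O)c1ccc(CNc2nc(Cl)nc3c2ncn3Cc2ccccc2)cc1` has not yet been measured in this assay. It differs from compound 1 in one place: phenyl in place of 2,2-dimethoxyethyl on a saturated chain carbon bound to an aromatic nitrogen. Going by the values given here, no pair of measured compounds separated by a single change is available, so the size of this step can only be expected, not derived. Given that compound 1, compound 2 and compound 3 all read low, no step beyond the scatter is expected in this assay. For compound 4 the expected value is 8%, with a range from 0% to 22%. That estimate means an expected step of a number 0.5 percentage points lower from compound 1 to compound 4 (within the scatter), within the scatter.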

Compound 4, a percentage reported as inhibition, at one concentration (the size of the read-out at that concentration, not a potency): 5.01%
Compound 4: middle estimate off by 3 percentage points, on the high side; measured number inside the range.
By their numbers in this assay, from the lowest: compounds 3, 2, 4 and 1 (each within the scatter of the next).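

Going by these compounds alone, the exchange of 2,2-dimethoxyethyl for phenyl gives the first single-change pair of the series: in this assay the step is a number 3.5 percentage points lower from compound 1 to compound 4 (within the scatter), on a saturated chain carbon bound to an aromatic nitrogen. At this place, a ring-free group with 2 hydrogen-bond acceptors and a six-membered aromatic ring of carbon only, with 0 such acceptors and the same 6 heavy atoms, cannot be told apart on this read-out. No measured property bears on this result.

Still open, on these data alone, is whether an amine or a carboxylic acid on a longer chain at this place would give a step beyond the scatter. Also open, as far as these compounds go, is whether compound 1 and compound 4 would separate at any other concentration.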